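The source may report more compounds than this note shows. Statements on the series, on what has been measured and on what is new or still open speak of the compounds shown alone.

Compound 3 `O=C(CN1CCN(c2nnc(Cc3ccncc3)c3ccccc23)CC1)Nc1cc(C(F)(F)F)ccc1Cl` sits second highest of the three numbers measured in a functional assay on HT-29 cells (Homo sapiens) for cytotoxicity, read by MTT assay, with a stated time of 72 h; on this read-out lower numbers stand for stronger inhibition and higher numbers for weaker inhibition: compound 3 gives 4810 nM, while compound 1 `O=C(CN1CCN(c2nnc(Cc3ccncc3)c3ccccc23)CC1)Nc1ccc(Br)cc1` gives 1990 nM and compound 2 `COc1ccc(NC(=O)CN2CCN(c3nnc(Cc4ccccc4)c4ccccc34)CC2)cc1OC` gives 145000 nM. Going by the values given here, the one step known, a 2.4-fold higher number from compound 1 to compound 3 (0.38 log units; beyond the scatter), is modest. Compound 4 `COc1ccc(NC(=O)CN2CCN(c3nnc(Cc4ccncc4)c4ccccc34)CC2)cc1OC` differs from compound 3 by 3,4-dimethoxyphenyl in place of 2-chloro-5-(trifluoromethyl)phenyl on an amide-type nitrogen. Among the compounds with values here, no measured step covers this exact change, but compound 2 also carries the 3,4-dimethoxyphenyl group on its amide-type nitrogen and gives the weakest number seen, so a large weakening step is expected for a 12-fold higher number from compound 3 to compound 4 (1.10 log units; beyond the scatter). Compound 4 is therefore estimated at 60000 nM in this assay, with a plausible range from 15000 nM to 200000 nM.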

Compound 4, half-maximal inhibitory concentration: 40100 nM
Beside the measured number, compound 4's estimate is 1.5-fold (0.18 log units) above it, within the range that was stated.
By their numbers in this assay, from the lowest: compound 1; then compound 3; then compound 4; then compound 2.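

With pyridin-4-yl held constant in this assay, the group on the amide-type nitrogen now shows a wider effect than the two halogen-bearing groups revealed, as 3,4-dimethoxyphenyl gives an 8.3-fold higher number from compound 3 to compound 4 (0.92 log units; beyond the scatter) and a 20-fold higher number from compound 1 to compound 4 (1.30 log units; beyond the scatter). Going by these compounds alone, the other site also registers for the first time, with pyridin-4-yl in place of phenyl on the saturated chain carbon giving a 3.6-fold lower number from compound 2 to compound 4 (0.56 log units; beyond the scatter). No supporting measurement explains either change. The compounds shown leave open how an amine or a carboxylic acid on the amide-type nitrogen's aryl group would read. They also leave open whether the pyridin-4-yl for phenyl step holds with halogen-bearing groups on that nitrogen.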